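Replacing the Chlorobenzyl Arm of Compound 1

The compounds below may be only part of what the source reports. "The series", "measured", "known", "first", "only" and "open" are said of these compounds alone.

Compound 1 `C[C@H](NC(=O)c1c(Cc2cccc(Cl)c2)sc2c1CCOC2)c1ccc(C(=O)O)cc1` blocks a cell-surface receptor. Within the data shown here, in a functional assay on CHO/Galpha16 cells for antagonist activity at prostaglandin E2 receptor EP4 subtype (Homo sapiens), read by calcium flux, with a stated time of 15 min (a higher number here means a weaker inhibitor, a lower number a stronger inhibitor), compound 1 gives 3.2 nM, the lowest of the two numbers measured so far. Its nearest neighbour is compound 2 `C[C@H](NC(=O)c1c(Cc2ccc(OC(F)(F)F)c(Cl)c2)sc2c1CCOC2)c1ccc(C(=O)O)cc1`, which in this assay gives 6.6 nM. Among the measured compounds shown here, the single measured step, a 2.1-fold higher number from compound 1 to compound 2 (0.31 log units; beyond the scatter), goes with a trifluoromethoxy in place of hydrogen on an aromatic carbon.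

Compound 3 `C[C@H](NC(=O)c1c(C#Cc2ccc(=O)[nH]c2)sc2c1CCOC2)c1ccc(C(=O)O)cc1` has not yet been measured. It differs from compound 1 in one place: a group of 9 heavy atoms (7 carbon, 1 nitrogen, 1 oxygen; one six-membered aromatic ring with 1 hetero atom) in place of a group of 8 heavy atoms (7 carbon, 1 chlorine; one six-membered aromatic ring of carbon only), on an aromatic carbon. The new group sits on an aromatic carbon of a five-membered aromatic ring with 1 sulfur, next to the ring sulfur.

For the measured compounds named here, no measured step bears closely on this change. Going by the values given here, the one step at hand adds a small group to the very ring that is now removed altogether, so it offers only a loose guide. A change of this size more often weakens than strengthens an inhibitor, and a modest weakening, a 4.7-fold higher number from compound 1 to compound 3 (0.67 log units; beyond the scatter), is the step expected here. Compound 3 is therefore estimated at 15 nM, with a range from 3 nM to 80 nM.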

Compound 3, half-maximal inhibitory concentration: 642 nM
Beside the measured number, compound 3's estimate is 43-fold (1.63 log units) below it; measured number above the stated range.
By their numbers in this assay, from the lowest: compound 1; then compound 2; then compound 3.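

At this position, on the aromatic carbon next to the ring sulfur, the arm of compound 1 proves far from interchangeable in this assay: swapping the 3-chlorobenzyl for a group that has a triple bond and a six-membered aromatic ring with a hetero atom gives a 200-fold higher number from compound 1 to compound 3 (2.30 log units; beyond the scatter) and so costs most of the inhibition. The earlier step of a 2.1-fold higher number from compound 1 to compound 2 (0.31 log units; beyond the scatter) showed only that a trifluoromethoxy can be added to the ring of the arm at a modest cost, whereas this result shows that replacing the arm as a whole can matter far more. Nothing measured here accounts for the size of this loss.

The change bundles several differences at once: the chlorine leaves, the link to the core gains a triple bond, the ring gains a hetero atom, and a hydrogen-bond donor and acceptor arrive, so these compounds cannot say which of them matters. From the compounds shown here alone, a phenylethynyl group or a plain benzyl at the same carbon would separate the link from the ring, and how either would behave remains open.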